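The source may report more compounds than this note shows. Statements on the series, on what has been measured and on what is new or still open speak of the compounds shown alone.

For the measured compounds named here, in an ADME assay on microsomes (Mus musculus) for metabolic stability, read by LC-MS (a lower number here means that the compound disappears faster, a higher number that the compound lasts longer), compound 2 `COc1cccc(-c2c(OC)cc(NC(C)CCCNC(=O)OC(C)(C)C)c3nc(C(F)(F)F)cc(C)c23)c1` gives 0.133 h, and this is the only plain number in the set. Compound 1 `COc1cc(NC(C)CCCN)c2nc(C(F)(F)F)cc(C)c2c1-c1cccc(C)c1` is reported as > 1 h, which is a limit of the assay rather than a number, so it sits at the limit of > 1 h in this assay, at which 1 of the 2 values shown sits. Compound 1 and compound 2 differ in more than one place, so their two values show only that one is a limit and the other a number.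

Compound 3 `COc1cc(NC(C)CCCNC(=O)OC(C)(C)C)c2nc(C(F)(F)F)cc(C)c2c1-c1cccc(C)c1` differs from compound 2 by methyl in place of methoxy on an aromatic carbon. Going by the values given here, no measured pair isolates this change, so its size is open. The expected step is a 2.3-fold higher number from compound 2 to compound 3 (0.35 log units; beyond the scatter), a modest lengthening of half-life that may not exceed the usual scatter. Compound 3 is therefore estimated at 0.3 h, with a range from 0.1 h to 1.2 h.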

Compound 3, half-life: 0.183 h
Beside the measured number, compound 3's estimate is 1.6-fold (0.21 log units) above it, within the range that was stated.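

In this assay, the swap from 3-methoxyphenyl to 3-methylphenyl gives a 1.4-fold higher number from compound 2 to compound 3 (0.14 log units; within the scatter), so with tert-butoxycarbonyl on the amine nitrogen, this pair cannot be told apart. For the compounds shown here, compound 3 also gives the first comparison with compound 1 that differs in one place: tert-butoxycarbonyl in place of hydrogen on an amine nitrogen gives an at least 5.4-fold lower number from compound 1 to compound 3 (0.73 log units; beyond the scatter), a step beyond the scatter whose full size remains unknown. The reading for compound 1 is a limit of the assay and not a number: the limit of > 1 h in this assay, at which 1 of the 3 values shown sits.

As far as these compounds go, it remains open whether the methoxy-to-methyl swap would also stay within the scatter on a compound with the free amine. From the compounds shown here alone, how a chlorine atom or a nitrile on that aromatic carbon, or an acetyl group on the amine nitrogen, would affect half-life is also open.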